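The compounds below may be only part of what the source reports. "The series", "measured", "known", "first", "only" and "open" are said of these compounds alone.

Working notes on the series.

Compound 1 `CC1CCC(C[C@H](NC(=O)c2ccco2)C(=O)N[C@H]2CC[C@@H](C)N(S(=O)(=O)c3ccccn3)CC2=O)CC1` and compound 2 `C[C@@H]1CC[C@H](NC(=O)[C@H](CCC2CCCC2)NC(=O)N2CCOCC2)C(=O)CN1S(=O)(=O)c1ccccn1` share the same core and differ in the side chain on the chiral carbon and in the group capping its amide nitrogen. In an assay on isolated protein for inhibition of cathepsin S (Homo sapiens), read by fluorescence (on this read-out lower numbers stand for stronger inhibition and higher numbers for weaker inhibition), compound 1 gives 0.5 nM. In this assay compound 2 gives 0.58 nM. The two numbers lie within the usual scatter of each other, so neither compound can be set apart from the other on this read-out; compound 1 simply stands at one end of a pair that the assay does not separate.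

Compound 3 `C[C@@H]1CC[C@H](NC(=O)[C@H](CC2CCCCCC2)NC(=O)c2ccco2)C(=O)CN1S(=O)(=O)c1ccccn1` has not yet been measured in this assay. It differs from compound 1 in one place: cycloheptyl in place of 4-methylcyclohexyl on a saturated chain carbon, two bonds along the chain from an amide-type nitrogen and a carbonyl carbon. The furan carbonyl cap and the rest of the molecule are kept. Going by the values given here, no measured pair isolates this kind of change, so no step is known for it.

For compound 3 the step of a 1.2-fold higher number from compound 1 to compound 3 (0.08 log units; within the scatter) is expected to be none beyond the scatter, since the saturated ring that enters is counted with the same number of carbon atoms as the one that leaves. Compound 3 is therefore estimated at 0.6 nM, with a range from 0.25 nM to 1.5 nM.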

Compound 3, half-maximal inhibitory concentration: < 0.4 nM
Compound 3 was reported as a limit; the forecaster's own chance of this, stated with the estimate: 0%; at least 1.5-fold (0.17 log units) between middle value and limit.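

In this assay compound 3 gives < 0.4 nM, which is a limit of the assay and not a number. Going by these compounds alone, this is the first step that can be read at this place, on a saturated chain carbon, two bonds along the chain from an amide-type nitrogen and a carbonyl carbon, and it reads an at least 1.2-fold lower number from compound 1 to compound 3 (0.09 log units; that floor lies within the scatter); with the furan carbonyl cap kept, the one-ring exchange of 4-methylcyclohexyl for cycloheptyl therefore shows no loss of inhibition, though the floor of the step alone does not set compound 3 apart from compound 1. The real size of the step stays unread, and the pair gives only its floor: the limit of < 0.4 nM in this assay, at which 1 of the 3 values shown sits.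

The compounds shown leave open whether a phenyl ring, an unsubstituted cyclohexyl or a piperidine amine on the same chain carbon would hold inhibition in the same way as the two saturated rings of carbon only. They also leave open whether cycloheptyl behaves alike when the furan carbonyl cap gives way to the cap carried by compound 2.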